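Methyl scan on a fused naphthyl series, growth inhibition

The source may hold more compounds than are shown below. What is called first, only, known or untested is meant among the compounds shown, and "the series" means these compounds.

Measured compounds:
compound 1 `Cc1cc(C)c2c(O)cc(-c3ccc4ccccc4c3)nc2n1` — 2950 nM
compound 2 `Oc1cc(-c2ccc3ccccc3c2)nc2ncccc12` — 1780 nM

In a functional assay on MDA-MB-435 cells (Homo sapiens) for antiproliferative activity (on this read-out higher numbers stand for weaker inhibition of growth and lower numbers for stronger inhibition of growth), compound 2 gives 1780 nM and compound 1 gives 2950 nM; the two numbers lie within the scatter of each other, so neither compound can be set apart on this read-out. Compound 3 `Cc1ccc2c(O)cc(-c3ccc4ccccc4c3)nc2n1` is not yet measured. It differs from compound 2 by methyl in place of hydrogen on an aromatic carbon. Going by the values given here, no step between measured compounds isolates this change. Given that compound 1 sits within the scatter of compound 2 in this assay, the step of a 1.2-fold higher number from compound 2 to compound 3 (0.09 log units; within the scatter) is expected to stay within the scatter. For compound 3 a value of 2200 nM is estimated, with a range from 1000 nM to 5000 nM.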

Compound 3, concentration for 50% growth inhibition: 1580 nM
Beside the measured number, compound 3's estimate is 1.4-fold (0.14 log units) above it; the range from low to high includes it.
By their numbers in this assay, from the lowest: compounds 3, 2 and 1 (each within the scatter of the next).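

In this assay, methyl on the aromatic carbon next to the ring nitrogen now has a step of its own: a 1.1-fold lower number from compound 2 to compound 3 (0.05 log units; within the scatter). The other methyl also has one, with hydrogen in its place giving a 1.9-fold lower number from compound 1 to compound 3 (0.27 log units; within the scatter), so neither methyl separates these compounds on this read-out. No further data bear on these steps. From the compounds shown here alone, whether an amine, a carboxylic acid or a longer chain on this aromatic carbon would give a step beyond the scatter stays open.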